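From acetamido to benzamido: working notes on growth inhibition

The source may report more compounds than this note shows. Statements on the series, on what has been measured and on what is new or still open speak of the compounds shown alone.

Within the data shown here, compound 1 (`COc1cccc(CN2CCC=C(CCC(=O)NO)C2=O)c1`) is the only compound with a number so far. In a functional assay on MDA-MB-231 cells (Homo sapiens) for inhibition, read by sulforhodamine B assay (a lower number here means a stronger inhibitor of growth, a higher number a weaker inhibitor of growth), compound 1 gives 3920 nM and serves as the sole reference point for the series.

Compound 2 (`CC(=O)Nc1ccc(CN2CCC=C(CCC(=O)NO)C2=O)cc1`) offers no such reference. In this assay, from the compounds shown here alone, compound 2 stands as "not determined" (no result reported) so its place remains open, and no comparison with compound 1 can be drawn.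

Compound 3 (`O=C(CCC1=CCCN(Cc2ccc(NC(=O)c3ccccc3)cc2)C1=O)NO`) is the next to be read. The structural change is phenyl in place of methyl on a carbonyl carbon with phenyl in place of methyl on a carbonyl carbon, which is acetamido to benzamido.

Among the measured compounds shown here, no measured step gives the size of this change in this assay and the data offer no direct guide. For the measured compounds named here, a modest move toward stronger growth inhibition is expected, near the edge of the usual scatter, measured against compound 1 at 3920 nM as the only available reading. Compound 3 is estimated at 2000 nM with an expected range of 500 nM to 8000 nM for its first reading.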

Compound 3, concentration for 50% growth inhibition: 6030 nM
Compound 3: middle estimate off by 3.0-fold (0.48 log units), on the low side, and the stated range covers the measured number.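

Among these compounds, compound 2 has no number in this assay and compound 3 gives 6030 nM, so no step between compound 2 and compound 3 can be read. The compounds shown leave open how large the change from acetamido to benzamido is in this assay. No available evidence bears on the reading for compound 3.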